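Swapping Methoxy for Methyl on the Fused Ring

The compounds below may be only part of what the source reports. "The series", "measured", "known", "first", "only" and "open" are said of these compounds alone.

Three compounds were tested in a functional assay on SEM cells (Homo sapiens) for cytotoxicity, read by MTT assay, with a stated time of 72 h; on this read-out lower numbers stand for stronger inhibition and higher numbers for weaker inhibition. Compound 1 `CCOC(=O)c1sc2cccc(C)c2c1Nc1cc(OC)c(OC)c(OC)c1` gives 1930 nM, compound 2 `COC(=O)c1sc2cc(OC)ccc2c1Nc1cc(OC)c(OC)c(OC)c1` gives 10.3 nM, and compound 3 `CCOC(=O)c1sc2c(OC)c(C)c(C)c(C)c2c1Nc1cc(OC)c(OC)c(OC)c1` gives 2.3 nM. Compound 2 thus stands second highest of the three numbers, and both of its gaps to the other compounds lie beyond the scatter. Compound 4 `COC(=O)c1sc2cc(C)ccc2c1Nc1cc(OC)c(OC)c(OC)c1` has not yet been measured. It differs from compound 2 in one place: methyl in place of methoxy on an aromatic carbon. Among the measured compounds shown here, no measured pair isolates this exact change. The expectation is therefore a small step, perhaps toward weaker inhibition, that may not exceed the scatter. The estimated step is a 1.9-fold higher number from compound 2 to compound 4 (0.29 log units; within the scatter). Compound 4 is expected to give about 20 nM, within a range from 5 nM to 100 nM.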

Compound 4, half-maximal inhibitory concentration: 0.7 nM
Compound 4: the middle estimate sits 29-fold (1.46 log units) above what was measured, and the stated range ends above it.
By their numbers in this assay, from the lowest: compound 4; then compound 3; then compound 2; then compound 1.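

In this assay, putting methyl in place of methoxy on this aromatic carbon gives a large change, a 15-fold lower number from compound 2 to compound 4 (1.17 log units; beyond the scatter), toward stronger inhibition. Among the compounds shown here, the earlier compounds differ in more than one place, so only this pair ties a step beyond the scatter to this single swap at this position. Nothing measured here explains the step.

As far as these compounds go, whether an amine or a longer chain at this position would keep the low number remains open. So does whether the same swap would give a similar step elsewhere on the core.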